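The compounds below may be only part of what the source reports. "The series", "measured", "known", "first", "only" and "open" are said of these compounds alone.

In a physicochemical assay for solubility, with a stated time of 4 h, at pH 7.4 (a lower number here means a less soluble compound, a higher number a more soluble compound), compound 1 (`CC(=O)CCc1cc(C)c(Oc2cc(Nc3ccc(C#N)cc3)c(N)cc2C(F)(F)F)c(C)c1`) gives 0.16 ug/mL and stands lowest of the two numbers in hand. Compound 2 (`COC(=O)c1cc(N)c(Nc2ccc(C#N)cc2)cc1Oc1c(C)cc(CCC#N)cc1C`) gives 1.21 ug/mL and lies higher than compound 1 by more than the usual scatter of repeats. For the measured compounds named here, these two compounds differ in more than one place, so their gap is not tied to any single change, and no single-change step has been measured so far.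

Next in line is compound 3 (`Cc1cc(/C=C/C#N)cc(C)c1Oc1cc(Nc2ccc(C#N)cc2)c(N)cc1C(F)(F)F`), not yet measured. It keeps the core of compound 1 and carries 2-cyanoethenyl in place of 2-acetylethyl on an aromatic carbon. Going by the values given here, with no measured step to calibrate this swap, the estimate starts from compound 1 at 0.16 ug/mL as the nearest reference. In this assay the expectation is a small step with no direction beyond the scatter. The estimated step (a 1.1-fold lower number from compound 1 to compound 3 (0.03 log units; within the scatter)) accordingly stays within the usual scatter. Compound 3 is estimated at 0.15 ug/mL with an expected range from 0.04 ug/mL to 0.6 ug/mL as the likely span.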

Compound 3, solubility: 0.24 ug/mL
The estimate for compound 3 lay 1.6-fold (0.20 log units) below the measured number; the range from low to high includes it.
By their numbers in this assay, from the lowest: compounds 1 and 3 (each within the scatter of the next); then compound 2.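

In this assay, the series now has its first single-change step, a 1.5-fold higher number from compound 1 to compound 3 (0.18 log units; within the scatter), for 2-cyanoethenyl in place of 2-acetylethyl on an aromatic carbon meta to two methyl groups and para to a large group. At this position, an unbranched group of 5 heavy atoms ending in a carbonyl and one of 4 heavy atoms ending in a nitrile, each with 1 hydrogen-bond acceptor and 0 hydrogen-bond donors, are not told apart by this read-out, since the step stays within the usual scatter. No separate measurement bears on this result, and the data offer no explanation for it.

Still open, going by these compounds, is whether an amine, a carboxylic acid or a longer chain on this aromatic carbon would give a step beyond the scatter. For the compounds shown here, the step also covers this one position only, so the places in which compound 2 differs from compound 1 have no single-change steps of their own.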